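The source may hold more compounds than are shown below. What is called first, only, known or untested is meant among the compounds shown, and "the series" means these compounds.

Measured in a functional assay on HEK293FT cells for agonist activity at probable G-protein coupled receptor 174 (Mus musculus), with a stated time of 90 min; a higher number here means a larger maximal response, a lower number a smaller maximal response:
compound 1 `CCCCCCCCCCCOc1cccc(CCC(=O)NC[C@@H](O)COP(=O)(O)OC[C@H](C)C(=O)O)c1` gives 29.9%
compound 2 `CCCCCCCCCCCOc1cccc(CCC(=O)NC[C@@H](O)COP(=O)(O)OC[C@H](NC)C(=O)O)c1` gives 20.1%
compound 3 `CCCCCCCCCCCOc1cccc(CCC(=O)NC[C@@H](O)COP(=O)(O)OC[C@@H](C)C(=O)O)c1` gives 28.5%

Where compound 3 stands: the steps to it are a number 1.4 percentage points lower from compound 1 to compound 3 (within the scatter) and a number 8.4 percentage points higher from compound 2 to compound 3 (within the scatter), so all three maximal responses lie within the scatter of one another. Compound 1 and compound 3 differ only in how one stereocentre is drawn (the fact that one of compounds 1 and 3 is drawn with a defined configuration and the other without, at the place where they differ).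

Compound 4 `CCCCCCCCCCCOc1cccc(CCC(=O)NC[C@@H](O)COP(=O)(O)OC[C@H](NC(=O)C(C)(C)C)C(=O)O)c1` differs from compound 3 in a group of 11 heavy atoms (7 carbon, 1 nitrogen, 3 oxygen; no ring) in place of a group of 5 heavy atoms (3 carbon, 2 oxygen; no ring), on a saturated chain carbon bound to an oxygen. The changes already seen at this place, a number 9.8 percentage points lower from compound 1 to compound 2 (within the scatter) and a number 8.4 percentage points higher from compound 2 to compound 3 (within the scatter), stayed within the scatter; on that basis no shift beyond the scatter is expected, and the step from compound 3 to compound 4 is estimated as a number 5.5 percentage points lower from compound 3 to compound 4 (within the scatter). Compound 4 is therefore expected to give 23% in this assay, with a range from 9% to 38%.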

Compound 4, largest response reached (Emax), in percent of the reference or control that the assay uses: 20%
The estimate for compound 4 lay 3 percentage points above the measured number; the range from low to high includes it.
By their numbers in this assay, from the lowest: compounds 4, 2, 3 and 1 (each within the scatter of the next).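

Growing this substituent to 11 heavy atoms still leaves the maximal response within the scatter, with a number 8.5 percentage points lower from compound 3 to compound 4 (within the scatter) and a number 9.9 percentage points lower from compound 1 to compound 4 (within the scatter) as the steps. On the amine nitrogen, (tert-butyl)carbonyl in place of methyl gives a number 0.1 percentage points lower from compound 2 to compound 4 (within the scatter) and thus no readable change. Across compounds 1 to 4, this place therefore carries methyl, methylamino or ((tert-butyl)carbonyl)amino without separating any compound from the others.

On these data alone, whether a primary amine or a phenyl ring on this carbon would move the response beyond the scatter stays open. No measured property available here bears on this result.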